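Reading the step from compound 2 to compound 4

A few compounds are considered here, and "the series" means these few. Any claim that something is new, unique, unknown or untested is made for them only; others in the source may bear on it.

Three compounds of the series have entries so far. In a physicochemical assay for permeability, using PAMPA (a higher number here means that the compound crosses the layer faster, a lower number that the compound crosses the layer more slowly), compound 1 (`Cc1ccc(C)c(-c2nc(CN3CCC(C(=O)NCCCN4C[C@H](C)C[C@H](C)C4)CC3)c(C)o2)c1`) stands with the entry "not determined" (no result reported) and gives no result. Compound 3 (`Cc1oc(-c2ccc(F)cc2)nc1CN1CCC(C(=O)NCCCN2C[C@H](C)C[C@H](C)C2)CC1`) carries the entry "not determined" (no result reported) and gives no result either. Compound 2 (`Cc1ccccc1-c1nc(CN2CCC(C(=O)NCCCN3CC(C)(C)CC(C)(C)C3)CC2)c(C)o1`) reads > 1390 10^-6 cm/s as its apparent permeability, and this is a limit of the assay, not a number. Among the compounds with values here, it is the only reading available, so compound 2 has no measured neighbour to be set against.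

Compound 4 (`Cc1ccccc1-c1nc(CN2CCC(C(=O)NCCCN3CCCC(CC(C)C)C3)CC2)c(C)o1`) has the same atoms as compound 2, joined differently, with a group of 10 heavy atoms (9 carbon, 1 nitrogen; one six-membered non-aromatic ring with 1 hetero atom) in place of a group of 10 heavy atoms (9 carbon, 1 nitrogen; one six-membered non-aromatic ring with 1 hetero atom), on a saturated chain carbon, three bonds along the chain from an amide-type nitrogen as the change, on a saturated chain carbon, three bonds along the chain from an amide-type nitrogen. One six-membered non-aromatic ring with 1 hetero atom thus replaces another.

Within the data shown here, no step between measured compounds exists, so the series supplies no size for such a change. In this assay no step beyond the scatter is expected, and the estimated step that the limit leaves unreadable from compound 2 to compound 4 stays within it. That expectation rests on compound 2 alone, whose > 1390 10^-6 cm/s is a limit. The assay may well report only a limit again. For compound 4 the estimate is 1400 10^-6 cm/s with an expected range from 600 10^-6 cm/s to 2500 10^-6 cm/s as the working figure.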

Compound 4, apparent permeability: 3 10^-6 cm/s
For compound 4 the middle estimate is 470-fold (2.67 log units) above the measured one; the whole stated range lies above it.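

Compound 4 gives the series its first readable step: in this assay, exchanging one six-membered non-aromatic ring with 1 hetero atom for another, on a saturated chain carbon, three bonds along the chain from an amide-type nitrogen, gives an at least 460-fold lower number from compound 2 to compound 4 (2.66 log units; beyond the scatter). The two groups match in everything counted here, with 10 heavy atoms each, 0 hydrogen-bond donors, 1 hydrogen-bond acceptor and no net charge, so this position responds strongly to how the same atoms are joined, and that composition alone does not settle the reading. Compound 2 reads > 1390 10^-6 cm/s, which is a limit of the assay and not a number, so the size of the step is a lower bound only: the limit of > 1390 10^-6 cm/s in this assay, at which 1 of the 4 values shown sits.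

The compounds shown leave open whether a comparable step appears with a different aryl group on the shared core, since this single pair gives the only comparison in the series. They also leave open where a ring of another kind at this place, such as morpholine, or an open-chain diethylamino group would fall in this assay.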